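Trading a Trifluoromethylphenyl for a Fluorophenyl Group

The compounds below may be only part of what the source reports. "The series", "measured", "known", "first", "only" and "open" are said of these compounds alone.

Measured so far:
Compound 1, `Nc1scc(CN2CCN(c3ccc(Cl)cc3Cl)CC2)c1C(=O)c1ccc(Cl)cc1`, gives -11% in a functional assay on CHO cells with adenosine receptor A1 (Homo sapiens) as the target, read by cAMP accumulation and immunoassay, with a stated time of 6 min, tested at 0.1 uM; a lower number here means a stronger effect, a higher number a weaker effect of the compound at the concentration tested.
Compound 2, `Nc1scc(CN2CCN(c3ccccc3C(F)(F)F)CC2)c1C(=O)c1ccc(Cl)cc1`, gives -7.5% in this assay.
Compound 3, `Nc1scc(CN2CCN(c3ccc(C(F)(F)F)cc3)CC2)c1C(=O)c1cccc(C(F)(F)F)c1`, gives -11% in this assay.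

Compound 2 shows the highest of the three numbers, yet its gaps to compound 1 and compound 3 are both within the scatter of repeated measurements, so no order among the three can be claimed. Going by the values given here, the one measured step that touches the group on the ring nitrogen, a number 3.5 percentage points higher from compound 1 to compound 2 (within the scatter), is itself within the scatter.

The next compound, compound 4, `Nc1scc(CN2CCN(c3cccc(F)c3)CC2)c1C(=O)c1ccc(Cl)cc1`, differs from compound 2 in one place: 3-fluorophenyl in place of 2-(trifluoromethyl)phenyl on an amine nitrogen in a ring. That is the same kind of exchange as the step from compound 1 to compound 2, which did not move the read-out beyond the scatter. The expected step from compound 2 to compound 4 is therefore a number 1.5 percentage points lower from compound 2 to compound 4 (within the scatter), no change beyond the scatter in this assay. Compound 4 is thus estimated at -9%, with a range from -20% to 3%.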

Compound 4, a percentage reported as activity, at one concentration (the size of the read-out at that concentration, not a potency): -37%
The estimate for compound 4 lay 28 percentage points above the measured number; the whole stated range lies above it.
By their numbers in this assay, from the lowest: compound 4; then compounds 1, 3 and 2 (each within the scatter of the next).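

In this assay, the group on the ring nitrogen can move the read-out: the step of a number 29.5 percentage points lower from compound 2 to compound 4 (beyond the scatter) and the step of a number 26 percentage points lower from compound 1 to compound 4 (beyond the scatter) both lie beyond the scatter, unlike the earlier step of a number 3.5 percentage points higher from compound 1 to compound 2 (within the scatter). Among the groups shown, 3-fluorophenyl therefore stands apart from both 2-(trifluoromethyl)phenyl and 2,4-dichlorophenyl, which remain within the scatter of each other. No measurement offered here accounts for this difference.

The compounds shown leave open whether the fluorine or the loss of the other substituents carries the step; a plain phenyl or a 3-chlorophenyl on the same nitrogen would speak to that. Going by these compounds, it is also open whether 3-fluorophenyl gives a similar step when the carbonyl carries the 3-(trifluoromethyl)phenyl of compound 3.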